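The compounds below may be only part of what the source reports. "The series", "measured", "known", "first", "only" and "open" are said of these compounds alone.

In an ADME assay for permeability, using PAMPA, with a stated time of 4 h, at pH 7.4; on this read-out higher numbers stand for higher permeability and lower numbers for lower permeability:

compound 1 `NCCCCN(C[C@H]1Cc2ncccc2CN1)[C@H]1CCCc2cccnc21` gives 14 nm/s
compound 2 `NC(=O)NC/C=C/CN(C[C@H]1Cc2ncccc2CN1)[C@H]1CCCc2cccnc21` gives 2 nm/s
compound 3 `CCN(CC)CCCCN(C[C@H]1Cc2ncccc2CN1)[C@H]1CCCc2cccnc21` gives 240 nm/s

Compound 1 stands second highest of the three numbers: compound 2 sits lower, a 7.0-fold lower number from compound 1 to compound 2 (0.85 log units; beyond the scatter), while compound 3 sits higher, a 17-fold higher number from compound 1 to compound 3 (1.23 log units; beyond the scatter). Compound 4 `CN(CCCCN(C[C@H]1Cc2ncccc2CN1)[C@H]1CCCc2cccnc21)C1CCOCC1` differs from compound 1 in one place: methyl(oxan-4-yl)amino in place of amino on a saturated chain carbon, four bonds along the chain from an amine nitrogen. The measured step that bears on this is the one where diethylamino in place of amino gave a 17-fold higher number from compound 1 to compound 3 (1.23 log units; beyond the scatter). Compound 4 likewise replaces the amino group in that place, and an upward step beyond the scatter in this assay is therefore expected, though a smaller one than the step to compound 3 is judged more likely. For compound 4 the expected step is a 5.7-fold higher number from compound 1 to compound 4 (0.76 log units; beyond the scatter), giving an estimate of 80 nm/s with a range from 25 nm/s to 250 nm/s.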

Compound 4, apparent permeability: 490 nm/s
Estimate against measurement, compound 4: 6.1-fold (0.79 log units) below; the whole stated range lies below it.
By their numbers in this assay, from the lowest: compound 2; then compound 1; then compound 3; then compound 4.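

In this assay this place, on a saturated chain carbon four bonds along the chain from an amine nitrogen, accepts a six-membered non-aromatic ring with a hetero atom without any loss: the change from amino to methyl(oxan-4-yl)amino gives a 35-fold higher number from compound 1 to compound 4 (1.54 log units; beyond the scatter) and the change from diethylamino gives a 2.0-fold higher number from compound 3 to compound 4 (0.31 log units; beyond the scatter), a modest further rise. The widest gap in the set is now a 250-fold higher number from compound 2 to compound 4 (2.39 log units; beyond the scatter), and compound 4 stands highest of the four. Nothing measured here explains the rise. Going by these compounds, whether a morpholine or piperidine at the chain end would do the same, and whether a shorter chain would keep the gain, stays open.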